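Swapping a propylamino chain for a piperidinyl ring

A few compounds are considered here, and "the series" means these few. Any claim that something is new, unique, unknown or untested is made for them only; others in the source may bear on it.

Measured so far:
compound 1 `CN(C)c1ccc(C(=O)N2CCCCc3ccccc32)c(Cl)c1`: 18 nM
compound 2 `CCCNc1ccc(C(=O)N2CCCCc3ccccc32)c(Cl)c1`: 18 nM
compound 3 `O=C(c1ccc(N2CCCC2)cc1)N1CCCCc2cc(Cl)ccc21`: 210 nM

All three were tested in an assay on HeLa cells for binding affinity to Vasopressin V2 receptor (Homo sapiens); a lower number here means a stronger inhibitor, a higher number a weaker inhibitor. Compound 2 sits level with compound 1 within the scatter, and together they give the lowest numbers of the three, while compound 3 gives a higher one. Among the measured compounds shown here, the only single-place step measured, no change at the digits printed from compound 1 to compound 2 (within the scatter), changed nothing.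

Compound 4 `O=C(c1ccc(N2CCCCC2)cc1Cl)N1CCCCc2ccccc21` has not yet been measured. It differs from compound 2 in one place: piperidin-1-yl in place of propylamino on an aromatic carbon. For the measured compounds named here, no measured step tests a ring in place of a chain here; compound 3 carries a ring but differs in more than one place, so its value is not a step. Because no change at the digits printed from compound 1 to compound 2 (within the scatter) showed no change, compound 4 is expected to stay close, a 1.4-fold higher number from compound 2 to compound 4 (0.14 log units; within the scatter). The estimate for compound 4 is 25 nM, ranging from 8 nM to 80 nM.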

Compound 4, half-maximal inhibitory concentration: 120 nM
Compound 4: middle estimate off by 4.8-fold (0.68 log units), on the low side; measured number above the stated range.
By their numbers in this assay, from the lowest: compounds 1 and 2 (each within the scatter of the next); then compounds 4 and 3 (each within the scatter of the next).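

In this assay this position does not treat all amino groups alike: piperidin-1-yl in place of propylamino gives a 6.7-fold higher number from compound 2 to compound 4 (0.82 log units; beyond the scatter) and piperidin-1-yl in place of dimethylamino gives a 6.7-fold higher number from compound 1 to compound 4 (0.82 log units; beyond the scatter) even though exchanging the two open-chain groups changed nothing beyond the scatter. So a ring at this aromatic carbon can cost binding that the chain swap did not reveal. Nothing measured here accounts for this rise.

Still open, from the compounds shown here alone, is whether the ring itself matters or its size. A morpholine ring or a hexylamino chain at this carbon could help separate the two.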